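Replacing a carbamate by a cyclic amidine on the piperidine nitrogen

The source may report more compounds than this note shows. Statements on the series, on what has been measured and on what is new or still open speak of the compounds shown alone.

Measured so far:
compound 1, `CC(C)OC(=O)N1CCC(Oc2ncnc3c2CCN3c2ccc(C#N)cc2F)CC1`, 134%
compound 2, `CCCOC(=O)N1CCC(Oc2ncnc3c2CCN3c2ccc(S(C)(=O)=O)cc2F)CC1`, 111%
compound 3, `CC(C)c1noc(N2CCC(O)CC2)n1`, 105%

In a functional assay on CHO-K1 cells with Glucose-dependent insulinotropic receptor (Homo sapiens) as the target, read by a luciferase reporter, with a stated time of 5 h (on this read-out lower numbers stand for smaller maximal responses and higher numbers for larger maximal responses), compound 2 gives 111%, the second highest of the three numbers. Its nearest neighbour is compound 3, whose value sits within the scatter of it; the furthest is compound 1, whose higher value lies beyond the scatter. Among the measured compounds shown here, no single-change step between measured compounds is available, so the effect of the next change cannot be read from a precedent.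

Compound 4, `CS(=O)(=O)c1ccc(N2CCc3c(OC4CCN(C5=NCCCN5)CC4)ncnc32)c(F)c1`, differs from compound 2 in one place: a group of 6 heavy atoms (4 carbon, 2 nitrogen; one six-membered non-aromatic ring with 2 hetero atoms) in place of a group of 6 heavy atoms (4 carbon, 2 oxygen; no ring), on an amine nitrogen in a ring. Both groups count six heavy atoms, so the size of the molecule hardly changes. The expected step from compound 2 to compound 4 is a number 1 percentage points lower from compound 2 to compound 4 (within the scatter), that is, no shift beyond the scatter in either direction. Compound 4 is therefore estimated to give 110%, within a range from 85% to 135%.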

Compound 4, largest response reached (reported as percent of maximum), in percent of the reference or control that the assay uses: 66%
Compound 4: the middle estimate sits 44 percentage points above what was measured; measured number below the stated range.
By their numbers in this assay, from the lowest: compound 4; then compounds 3 and 2 (each within the scatter of the next); then compound 1.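

Compound 4 shows that the group on this amine nitrogen in a ring strongly shapes the maximal response. In this assay, the cyclic amidine in place of propoxycarbonyl gives a number 45 percentage points lower from compound 2 to compound 4 (beyond the scatter). Matching heavy-atom counts therefore did not keep the response level, and no available measurement explains the drop.

As far as these compounds go, whether the drop follows from the ring itself or from the added hydrogen-bond donor remains open. An open-chain amidine or a urea on the same nitrogen could help separate the two.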